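Amine swap at the thiocarbonyl carbon: compound 2 to compound 4

The source may hold more compounds than are shown below. What is called first, only, known or untested is meant among the compounds shown, and "the series" means these compounds.

The series shares one core and varies the amine attached to the thiocarbonyl carbon. Compound 1 `Nc1ccccc1NC(=O)c1ccc(CSC(=S)N2CCN(c3ccc(Cl)cc3)CC2)cc1` gives 29% in a functional assay on A-375 cells (Homo sapiens) for antiproliferative activity, read by CCK-8 assay, with a stated time of 72 h, tested at 8 uM; a higher number here means a stronger effect of the compound at the concentration tested, a lower number a weaker effect. Compound 2 `Nc1ccccc1NC(=O)c1ccc(CSC(=S)N2CCc3ccccc32)cc1` gives 85.4% in this assay, and compound 3 `Nc1ccccc1NC(=O)c1ccc(CSC(=S)N2CCN(Cc3cccnc3)CC2)cc1` gives 89.2% in this assay. Compound 2 stands second highest of the three numbers: compound 3 lies nearest, within the scatter, and compound 1 lies furthest, beyond the scatter. For the measured compounds named here, the only single-point step measured so far is a number 60.2 percentage points higher from compound 1 to compound 3 (beyond the scatter), a large gain.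

Compound 4 `CN(Cc1ccncc1)C(=S)SCc1ccc(C(=O)Nc2ccccc2N)cc1` is not yet measured. Relative to compound 2 the change is methyl((pyridin-4-yl)methyl)amino in place of 2,3-dihydro-1H-indol-1-yl on a thiocarbonyl carbon. Going by the values given here, no measured step replaces the whole amine on the thiocarbonyl carbon; the step from compound 1 to compound 3 changes only a substituent on an amine nitrogen in a ring, so it bears on compound 4 only loosely. Among the compounds with values here, what the numbers do show is that compound 2 and compound 3 carry quite different amines and still sit within the scatter of each other, while compound 1 with its 4-chlorophenyl is the one low value. Compound 4 carries a pyridine like compound 3, so an expected step of a number 7.4 percentage points lower from compound 2 to compound 4 (within the scatter) in this assay is within the scatter. Compound 4 is therefore estimated at 78% in this assay, with a range of 55% to 92%.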

Compound 4, a percentage reported as inhibition, at one concentration (the size of the read-out at that concentration, not a potency): 86.1%
Compound 4: the middle estimate sits 8.1 percentage points below what was measured; measured number inside the range.
By their numbers in this assay, from the lowest: compound 1; then compounds 2, 4 and 3 (each within the scatter of the next).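

At the thiocarbonyl carbon, the whole amine can be exchanged with no readable consequence in this assay: a number 0.7 percentage points higher from compound 2 to compound 4 (within the scatter) replaces the ring-closed 2,3-dihydro-1H-indol-1-yl with the open-chain methyl((pyridin-4-yl)methyl)amino. The exchange swaps a carbon-only aromatic ring for one with a hetero atom and adds a hydrogen-bond acceptor while the heavy-atom count stays the same, so neither the closed five-membered ring nor the carbon-only aromatic ring is needed for the effect at this single concentration, which is a size of effect and not a potency. No measurement at hand explains this result.

Still open, from the compounds shown here alone, is how far this latitude extends at the thiocarbonyl carbon, for example to an amine carrying a longer chain such as ethyl or butyl in place of the methyl, or to a morpholine. Also open is whether a carboxylic acid on the pyridine ring of methyl((pyridin-4-yl)methyl)amino would keep the effect, and whether potency differences exist among these amines that a reading at one concentration cannot separate.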